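Lengthening the Amide Chain from Methyl to Ethyl

A few compounds are considered here, and "the series" means these few. Any claim that something is new, unique, unknown or untested is made for them only; others in the source may bear on it.

Compound 1 `CNC(=O)c1cc(Oc2ccc(NC(=O)c3cc4cccnc4n(-c4ccccc4)c3=O)cc2)ccn1` was tested in a functional assay on U-87MG ATCC cells for antiproliferative activity against U-87 MG (Homo sapiens), read by MTT assay, with a stated time of 72 h (on this read-out lower numbers stand for stronger inhibition and higher numbers for weaker inhibition), where compound 1 gives 1820 nM. Among the compounds with values here, only one other compound has been measured alongside it: compound 2 `CNC(=O)c1cc(Oc2ccc(NC(=O)c3cc4cccnc4n(-c4ccc(C(F)(F)F)cc4Cl)c3=O)cc2)ccn1`, which carries a larger substituent on an aromatic nitrogen of the shared core; in this assay compound 2 gives 19800 nM. Within the data shown here, the one recorded step, an 11-fold higher number from compound 1 to compound 2 (1.04 log units; beyond the scatter), sits at that nitrogen-bound ring. Among these two numbers compound 1 therefore holds the lower one.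

Compound 3 `CCNC(=O)c1cc(Oc2ccc(NC(=O)c3cc4cccnc4n(-c4ccccc4)c3=O)cc2)ccn1` keeps the phenyl on the aromatic nitrogen and changes a different part of the molecule: methyl in place of hydrogen on a saturated chain carbon bound to an amide-type nitrogen, so that the methylcarbamoyl end becomes an ethylcarbamoyl end. Among the measured compounds shown here, no measured step touches this position, and the step from compound 1 to compound 2 concerns a different change, so it offers no guide to the direction here. With nothing in the data pointing up or down, the expected step is a 1.1-fold higher number from compound 1 to compound 3 (0.04 log units; within the scatter), one that stays within the usual scatter. Compound 3 is therefore estimated at 2000 nM, with a range from 800 nM to 5000 nM.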

Compound 3, half-maximal inhibitory concentration: 2650 nM
Compound 3: middle estimate off by 1.3-fold (0.12 log units), on the low side, and the stated range covers the measured number.
By their numbers in this assay, from the lowest: compounds 1 and 3 (each within the scatter of the next); then compound 2.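

Moving to the other end of the molecule, the change from methylcarbamoyl to ethylcarbamoyl gives a 1.5-fold higher number from compound 1 to compound 3 (0.16 log units; within the scatter). In this assay, this first reading at this position shows that adding one carbon to the chain on the amide-type nitrogen leaves the number within the scatter of the parent value, so the two compounds cannot be told apart here. Within the data shown here, the only earlier step, at the ring on the aromatic nitrogen, was an 11-fold higher number from compound 1 to compound 2 (1.04 log units; beyond the scatter), so that ring change registers clearly in this small set while this chain change does not, and nothing available here offers a reason for this result.

On these data alone, it remains open whether a longer chain such as propyl, a branched one such as isopropyl, a ring such as cyclopropyl or a plain unsubstituted amide at this end would also stay within the scatter. As far as these compounds go, it is equally open whether ethylcarbamoyl would behave the same way with 2-chloro-4-(trifluoromethyl)phenyl, rather than phenyl, on the aromatic nitrogen.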